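The compounds below may be only part of what the source reports. "The series", "measured", "known", "first", "only" and "open" are said of these compounds alone.

In an ADME assay on HFF cells (Homo sapiens) for cytotoxicity, read by neutral red uptake (a higher number here means that more compound is tolerated, a lower number that less compound is tolerated), compound 1 `Nc1ncnc2c1ncn2/C=C1\C[C@H]1[C@H](O)CO` gives 194000 nM. Compound 2 `Nc1ncnc2c1ncn2/C=C1\C[C@@H]1[C@H](O)CO` gives > 300000 nM, which is a limit of the assay. Compound 3 `Nc1ncnc2c1ncn2/C=C1/C[C@@H]1[C@H](O)CO` gives > 300000 nM, which is also a limit, and the limit of > 300000 nM in this assay, at which 2 of the 3 values shown sit, is shared by both. Compound 4 `Nc1ncnc2c1ncn2/C=C1\C[C@H]1[C@@H](O)CO` has the same connectivity as compound 3, and the change is the two compounds have the same atoms and bonds and differ only in configuration as drawn: 3 of 3 stereo elements differ; a stereocentre at a saturated ring carbon is drawn S in compound 3 and R in compound 4; a stereocentre at a saturated chain carbon is drawn S in compound 3 and R in compound 4; a double bond is drawn Z in compound 3 and E in compound 4. The ring stereocentre and double bond changed in the opposite sense in an at least 1.5-fold higher number from compound 1 to compound 3 (0.18 log units; that floor lies within the scatter), and the ring stereocentre changed alone in an at least 1.5-fold higher number from compound 1 to compound 2 (0.18 log units; that floor lies within the scatter). Going by the values given here, no measured step changes the chain stereocentre, so its contribution is unknown. Read backwards, these steps suggest an expected change of an at least 1.2-fold lower number from compound 3 to compound 4 (0.09 log units; that floor lies within the scatter), a small move toward less compound tolerated. For compound 4, the estimated value is 240000 nM, with an expected range of 130000 nM to 400000 nM.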

Compound 4, half-maximal cytotoxic concentration: 264000 nM
Estimate against measurement, compound 4: 1.1-fold (0.04 log units) below; low and high end bracket the measured number.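

In this assay, going by these compounds alone, the chain stereocentre changes alone, which no earlier step showed (a 1.4-fold higher number from compound 1 to compound 4 (0.13 log units; within the scatter)), so this swap on its own gives no shift beyond the scatter. Two further steps start from a limit of the assay and so give only floors (an at least 1.1-fold lower number from compound 2 to compound 4 (0.05 log units; that floor lies within the scatter)) and (an at least 1.1-fold lower number from compound 3 to compound 4 (0.05 log units; that floor lies within the scatter)).

Going by these compounds, the true size of those two steps stays open, as does the effect of the chain stereocentre with the double bond drawn Z. Also open is whether an amine in place of a hydroxyl group, or a longer chain, would change how much compound is tolerated.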